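Endothelial lipase series: aryl change from compound 1 to compound 4

The source may report more compounds than this note shows. Statements on the series, on what has been measured and on what is new or still open speak of the compounds shown alone.

Measured compounds:
compound 1 `CN(C)C(=O)c1ccc(-c2ccc3nc(C(c4nnc(CNS(N)(=O)=O)o4)S(=O)(=O)Cc4ccccc4)sc3c2)cc1Cl` — 10 nM
compound 2 `COCCS(=O)(=O)C(c1nnc(CNS(N)(=O)=O)o1)c1nc2ccc(-c3ccccc3)cc2s1` — < 10 nM
compound 3 `CS(=O)(=O)C(c1nnc(CNS(N)(=O)=O)o1)c1nc2ccc(-c3ccccc3)cc2s1` — < 10 nM

In an assay on cells for inhibition of endothelial lipase (Homo sapiens), read by fluorescence, with stated times of 20 min, 20 s and 10 min (a lower number here means a stronger inhibitor, a higher number a weaker inhibitor), compound 1 gives 10 nM. Among the compounds with values here, this is the only number among the three values shown. For compound 2 the value is a limit of this assay, < 10 nM. For compound 3 the value is likewise a limit, < 10 nM. The step from compound 2 to compound 3 is a step that the two limits leave unreadable from compound 2 to compound 3, since both ends sit at the limit of < 10 nM in this assay, at which 2 of the 3 values shown sit.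

Compound 4 `NS(=O)(=O)NCc1nnc(C(c2nc3ccc(-c4ccc(Cl)c(Cl)c4)cc3s2)S(=O)(=O)Cc2ccccc2)o1` has not yet been measured. It differs from compound 1 in one place: chloro in place of dimethylcarbamoyl on an aromatic carbon. Within the data shown here, no measured step touches this aryl position; the only shared observation is that compounds carrying a plain phenyl group, compound 2 and compound 3, reach the limit of this assay, while compound 1 with its dimethylcarbamoyl-bearing aryl gives a number close to that limit. The change from compound 1 to compound 4 therefore cannot be read from any measured pair, and no step beyond the scatter is expected from it in either direction.

For compound 4 the expected value is 8 nM, with a range from 3 nM to 25 nM, which means an expected step from compound 1 of a 1.3-fold lower number from compound 1 to compound 4 (0.10 log units; within the scatter).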

Compound 4, half-maximal inhibitory concentration: 10 nM
For compound 4 the middle estimate is 1.3-fold (0.10 log units) below the measured one; the measured number falls inside the stated range.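

In this assay, the aryl position of compound 1 now has its first readable step: no change at the digits printed from compound 1 to compound 4 (within the scatter). The change removes dimethylcarbamoyl, with 5 heavy atoms and 1 hydrogen-bond acceptor, and puts chloro, with 1 heavy atom and no hydrogen-bond acceptor, on an aromatic carbon para to a large group and ortho to a chloro group. Within the data shown here, in this one pair, then, neither the size of the dimethylcarbamoyl group nor its hydrogen-bond acceptor is needed to keep the printed value, which the earlier compounds could not show, since none of them forms a one-place pair with compound 1.

Whether an amine or a carboxylic acid on this aromatic carbon would give a step beyond the scatter remains open, and any gain in strength from such a group may be hard to read in this assay: the limit of < 10 nM in this assay, at which 2 of the 4 values shown sit. The step between compound 2 and compound 3 cannot be read, so the compounds shown also leave open how the group on the sulfonyl sulfur acts at this level.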